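From imidazolyl to piperidinyl on a shared core

This account rests on a few compounds, and the source may have more. Where it says the series, first, only, none or still open, it means among the compounds named here.

Values in a functional assay on C6 cells (Rattus norvegicus) for inhibition, read by sulforhodamine B assay, with a stated time of 72 h (on this read-out higher numbers stand for an effect only at larger amounts of compound and lower numbers for an effect already at smaller amounts), stand as follows:
compound 1 `CCC(=O)Oc1cccc2ccc(/C=C/c3ccccc3[N+](=O)[O-])nc12` gives 6300 nM
compound 2 `O=C(/C=C/c1ccc([N+](=O)[O-])o1)c1ccc(Br)cc1` gives 2700 nM
compound 3 `O=C(/C=C/c1ccc([N+](=O)[O-])o1)c1ccc(-n2ccnc2)cc1` gives 3500 nM

Compound 3 is not separated from the other two, since its number lies within the scatter of both compound 2 and compound 1. Still unmeasured, compound 4 `O=C(/C=C/c1ccc([N+](=O)[O-])o1)c1ccc(N2CCCCC2)cc1` carries piperidin-1-yl in place of 1H-imidazol-1-yl on an aromatic carbon and otherwise keeps the core of compound 3. For the measured compounds named here, only one measured exchange bears on this place: 1H-imidazol-1-yl in place of bromo gave a 1.3-fold higher number from compound 2 to compound 3 (0.11 log units; within the scatter) in this series. That single step is thin evidence and it says nothing about a non-aromatic ring, but it offers no reason to expect a step beyond the scatter in either direction. The expected step is a 1.2-fold lower number from compound 3 to compound 4 (0.07 log units; within the scatter) by this estimate. Compound 4 is expected at 3000 nM within a range of 1200 nM to 7500 nM in this assay once measured.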

Compound 4, half-maximal effective concentration: 48700 nM
Compound 4: middle estimate off by 16-fold (1.21 log units), on the low side; measured number outside the range, above it.
By their numbers in this assay, from the lowest: compounds 2, 3 and 1 (each within the scatter of the next, the first and the last beyond it); then compound 4.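

Piperidin-1-yl produced the first step beyond the scatter at this position, on an aromatic carbon para to a large group: in this assay the exchange for 1H-imidazol-1-yl gave a 14-fold higher number from compound 3 to compound 4 (1.14 log units; beyond the scatter), and the exchange for bromo gave an 18-fold higher number from compound 2 to compound 4 (1.26 log units; beyond the scatter). The earlier pair had shown only that bromo and 1H-imidazol-1-yl are not separated here, whereas this result shows that the number at this position does depend on the group it carries. Nothing available accounts for the size of this step.

The compounds shown leave open which feature of piperidin-1-yl goes with the step, for it differs from 1H-imidazol-1-yl in ring size, ring aromaticity and hetero atoms all at once. Also open, from the compounds shown here alone, is how morpholin-4-yl or an open-chain amine such as dimethylamino would read on this carbon.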